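Methyl on the Aryl Ring: Tolerance of Compound 4 in Vero Cells

A few compounds are considered here, and "the series" means these few. Any claim that something is new, unique, unknown or untested is made for them only; others in the source may bear on it.

Measured compounds:
- Compound 1, `CC/C(C)=N\NC(=S)N(Cc1ccccc1)Cc1ccccc1`: "not determined" (no result reported)
- Compound 2, `S=C(N/N=C\c1ccccc1)N(Cc1ccccc1)Cc1ccccc1`: 174000 nM
- Compound 3, `C=CCN(CC=C)C(=S)N/N=C\c1ccccc1[N+](=O)[O-]`: 205000 nM

Three thiosemicarbazones share this set. In an ADME assay on Vero cells (Chlorocebus sabaeus) for cytotoxicity, read by MTT assay, with a stated time of 72 h (a higher number here means that more compound is tolerated, a lower number that less compound is tolerated), compound 2 gives 174000 nM and compound 3 gives 205000 nM; for compound 1 the entry reads "not determined" (no result reported), so no number exists for it in this assay. Compound 2 thus holds the lower of the two numbers available, but its gap to compound 3 lies within the scatter of repeated measurements, so the two cannot be placed in any order. Going by the values given here, no step between two measured compounds that differ in one place is available here.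

The unmeasured compound 4, `Cc1ccccc1/C=N\NC(=S)N(Cc1ccccc1)Cc1ccccc1`, differs from compound 2 by methyl in place of hydrogen on an aromatic carbon. Among the compounds with values here, nothing among the measured compounds shows how such a change affects the numbers in this assay, so no size of step can be read from them. Given the small size of the change, compound 4 is expected to stay close to compound 2, with a step of a 1.1-fold lower number from compound 2 to compound 4 (0.04 log units; within the scatter) that should not exceed the scatter. Compound 4 is therefore estimated at 160000 nM, within a range from 80000 nM to 320000 nM.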

Compound 4, half-maximal cytotoxic concentration: 167000 nM
The estimate for compound 4 lay 1.0-fold (0.02 log units) below the measured number; measured number inside the range.
By their numbers in this assay, from the lowest: compounds 4, 2 and 3 (each within the scatter of the next).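

Going by these compounds alone, until now no step between two compounds differing in one place could be read, so the effect of any single change on the tolerated concentration was unknown. In this assay, within the data shown here, methyl in place of hydrogen on an aromatic carbon, ortho to a large group, gives a 1.0-fold lower number from compound 2 to compound 4 (0.02 log units; within the scatter), which makes this phenyl to 2-methylphenyl change the one single-place comparison in the set and shows that it leaves no difference that can be told apart from repeated measurement. Thus this position of the six-membered aromatic ring accepts a methyl group with no detectable effect on the number, although nothing at hand explains that outcome.

The compounds shown leave open whether an ethyl chain, a methoxy group, an amine or a carboxylic acid at this same place would also leave the number within the scatter, since methyl is the only group seen to replace hydrogen here. They also leave open whether methyl placed elsewhere on this ring would behave as it does in this one position.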